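Three amides on a shared core, and a fourth awaiting measurement

The source may hold more compounds than are shown below. What is called first, only, known or untested is meant among the compounds shown, and "the series" means these compounds.

Measured compounds:
- Compound 1, `C=C(CC)C(=O)c1ccc(OCC(=O)Nc2ccc3cc(C(=O)O)ccc3c2)c(Cl)c1Cl`: 3700 nM
- Compound 2, `C=C(CC)C(=O)c1ccc(OCC(=O)Nc2ccc3nc[nH]c3c2)c(Cl)c1Cl`: 3200 nM
- Compound 3, `C=C(CC)C(=O)c1ccc(OCC(=O)Nc2ccc3c(C)cc(=O)oc3c2)c(Cl)c1Cl`: 2800 nM

All three compounds were tested in a functional assay on CLL cells (Homo sapiens) for cytotoxicity, read by MTT assay, with a stated time of 48 h; on this read-out higher numbers stand for an effect only at larger amounts of compound and lower numbers for an effect already at smaller amounts. Compound 1 gives 3700 nM, compound 2 gives 3200 nM and compound 3 gives 2800 nM. Compound 2 holds the second highest of the three numbers, but the gap to compound 3 and the gap to compound 1 both lie within the usual scatter of repeated measurements, so no order among the three can be read from these values. In each case a different aromatic substituent sits on the amide-type nitrogen while the rest of the molecule stays the same, and the values sit close together.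

The next compound, compound 4, `C=C(CC)C(=O)c1ccc(OCC(=O)Nc2ccc(O)cc2)c(Cl)c1Cl`, has not yet been measured in this assay. It differs from compound 2 as follows: 4-hydroxyphenyl in place of 1H-benzimidazol-6-yl on an amide-type nitrogen. Within the data shown here, the three measured compounds show that exchanging the group on the amide-type nitrogen has so far left the numbers within the scatter of one another, and no single-change step between measured compounds is available to sharpen that picture. On this basis the step expected from compound 2 to compound 4 is estimated as a 1.1-fold higher number from compound 2 to compound 4 (0.03 log units; within the scatter), no larger than the scatter, in no particular direction. Compound 4 is therefore expected to give 3400 nM, with an estimated range from 1500 nM to 8000 nM.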

Compound 4, half-maximal effective concentration: 6400 nM
For compound 4 the middle estimate is 1.9-fold (0.27 log units) below the measured one; measured number inside the range.
By their numbers in this assay, from the lowest: compounds 3, 2, 1 and 4 (each within the scatter of the next, the first and the last beyond it).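

In this assay, putting 4-hydroxyphenyl in place of 1H-benzimidazol-6-yl on the amide-type nitrogen gives a 2.0-fold higher number from compound 2 to compound 4 (0.30 log units; within the scatter), so this change, which removes the five-membered aromatic ring and leaves one hydrogen-bond donor and one hydrogen-bond acceptor in the group, stays within the scatter. Among these compounds, the position nevertheless no longer looks entirely flat: compound 3 at 2800 nM and compound 4 at 6400 nM are the first pair whose values lie beyond the scatter of each other, which shows that the group on this nitrogen can shift the number by a modest amount. Nothing in the data shown explains that gap.

As far as these compounds go, what an unsubstituted phenyl, a 4-methoxyphenyl or a 4-aminophenyl would give on this nitrogen stays open, and with it whether the hydroxyl contributes anything to the number of compound 4. Also open, from the compounds shown here alone, is whether a cyclohexyl group or a short alkyl chain in this place would keep the numbers in the same narrow band, and how the values respond to changes elsewhere on the shared core.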